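Hydrazone series: removing the fluoro substituent

The source may report more compounds than this note shows. Statements on the series, on what has been measured and on what is new or still open speak of the compounds shown alone.

Measured compounds in a functional assay on PC-3 cells (Homo sapiens) for inhibition; a lower number here means a stronger inhibitor, a higher number a weaker inhibitor:
compound 1 `Cc1c(C(=O)N/N=C\c2ccc(O)cc2)oc2cccc(O)c12`, 21700 nM
compound 2 `Cc1c(C(=O)N/N=C\c2cc(F)ccc2O)oc2cccc(O)c12`, 3170 nM
compound 3 `Cc1c(C(=O)N/N=C\c2cccc(F)c2)oc2cccc(O)c12`, a limit only

Compound 3 sits at the assay limit, >= 40000 nM, so only a floor is known for it (the limit of >= 40000 nM in this assay, at which 1 of the 3 values shown sits). Among the three values it is the weakest reading, with an at least 1.8-fold higher number from compound 1 to compound 3 (0.26 log units; that floor lies within the scatter) and an at least 12-fold higher number from compound 2 to compound 3 (1.10 log units; beyond the scatter), the second of these beyond the scatter.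

Compound 4 `Cc1c(C(=O)N/N=C\c2ccccc2)oc2cccc(O)c12` differs from compound 3 by hydrogen in place of fluoro on an aromatic carbon. Among the measured compounds shown here, no measured pair shows this exact change. The two steps that lead into compound 3 concern the aromatic substituents: an at least 1.8-fold higher number from compound 1 to compound 3 (0.26 log units; that floor lies within the scatter) and an at least 12-fold higher number from compound 2 to compound 3 (1.10 log units; beyond the scatter), so a hydroxy on the benzylidene ring accompanies the stronger readings, and compound 3, carrying fluoro and no hydroxy, the weakest. Compound 4 carries neither hydroxy nor fluoro, so there is no ground to expect it to recover the hydroxy-linked gain of compound 1 or compound 2.

The expected step in this assay is therefore small, a number no higher from compound 3 to compound 4 (the limit leaves the size open), and compound 4 is estimated at 40000 nM, with a range from 15000 nM to 100000 nM, most likely again reported as a limit.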

Compound 4, half-maximal inhibitory concentration: 29200 nM
Estimate against measurement, compound 4: 1.4-fold (0.14 log units) above; measured number inside the range.
By their numbers in this assay, from the lowest: compound 2; then compounds 1 and 4 (each within the scatter of the next). At a limit, above all of these: compound 3.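

Compound 3 is held at a limit in this assay, >= 40000 nM, so 3-fluorophenyl to phenyl at this place on the six-membered aromatic ring can be read only as a floor, an at least 1.3-fold lower number from compound 3 to compound 4 (0.13 log units; that floor lies within the scatter), and the size of the fluoro change stays unknown: the limit of >= 40000 nM in this assay, at which 1 of the 4 values shown sits.

The plain phenyl ring does not match the ring of compound 2, a 9.2-fold higher number from compound 2 to compound 4 (0.96 log units; beyond the scatter), which leaves compound 2 alone as the strongest of the four compounds in this series. The hydroxy of compound 1 shows no gain over hydrogen, a 1.3-fold higher number from compound 1 to compound 4 (0.13 log units; within the scatter), so the large effect of losing a hydroxy seen with compound 2 does not carry over to compound 1, and the same change differs sharply with its surroundings: the same change on two cores in this assay, an at least 12-fold higher number (1.10 log units; beyond the scatter) from compound 2 to compound 3 and a 1.3-fold higher number (0.13 log units; within the scatter) from compound 1 to compound 4, at least 9.3-fold (0.97 log units) apart, beyond the scatter of two such steps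

Still open, on these data alone, is whether the reading of compound 2 rests on its hydroxy, its fluoro or the two together, and how far compound 3 lies past its limit. Also open, as far as these compounds go, is whether a methoxy or an amine in place of the hydroxy of compound 2 would hold its reading.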